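The source may report more compounds than this note shows. Statements on the series, on what has been measured and on what is new or still open speak of the compounds shown alone.

Three compounds share one core and differ only in the amine at the end of a chain attached through an oxygen on an aromatic ring. Compound 1 `COc1cc2c(Nc3ccc(C#N)cc3)ncnc2cc1OCCCN(C)C` carries a dimethylamino group there. In a functional assay on HepG2 cells (Homo sapiens) for antiproliferative activity, read by MTT assay, with a stated time of 72 h (a higher number here means a weaker inhibitor, a lower number a stronger inhibitor), compound 1 gives only a limit of the assay, > 100000 nM. Compound 2 `COc1cc2c(Nc3ccc(C#N)cc3)ncnc2cc1OCCCN1CCC(C)CC1` carries a 4-methylpiperidin-1-yl group instead, and in this assay compound 2 gives 32100 nM; that change is an at least 3.1-fold lower number from compound 1 to compound 2 (0.49 log units; beyond the scatter). Compound 3 `COc1cc2c(Nc3ccc(C#N)cc3)ncnc2cc1OCCCN1CCCCC1CCO` carries a 2-(2-hydroxyethyl)piperidin-1-yl group. In this assay compound 3 gives only a limit, > 100000 nM. Compound 3 therefore stands at the limit, and the limit of > 100000 nM in this assay, at which 2 of the 3 values shown sit, means that the step from compound 1 to compound 3, a step that the two limits leave unreadable from compound 1 to compound 3, cannot be sized, while the step from compound 2 to compound 3 is an at least 3.1-fold higher number from compound 2 to compound 3 (0.49 log units; beyond the scatter).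

Compound 4 `CCOC(=O)C1CCN(CCCOc2cc3ncnc(Nc4ccc(C#N)cc4)c3cc2OC)CC1` has not yet been measured. It differs from compound 3 by 4-(ethoxycarbonyl)piperidin-1-yl in place of 2-(2-hydroxyethyl)piperidin-1-yl on a saturated chain carbon, three bonds along the chain from an oxygen on an aromatic ring. The step that bears on it is an at least 3.1-fold higher number from compound 2 to compound 3 (0.49 log units; beyond the scatter): replacing the 2-(2-hydroxyethyl)piperidin-1-yl group with a piperidine that, like the 4-methylpiperidin-1-yl group of compound 2, carries no hydroxyl is expected to bring the number back down from the limit. Compound 4 is expected to give 50000 nM in this assay, within 15000 nM to 150000 nM. The step from compound 3 to compound 4 is expected to be an at least 2.0-fold lower number from compound 3 to compound 4 (0.30 log units; that floor lies within the scatter), though starting from a limit its size stays uncertain.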

Compound 4, half-maximal inhibitory concentration: 57700 nM
Beside the measured number, compound 4's estimate is 1.2-fold (0.06 log units) below it; the measured number falls inside the stated range.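

Compound 4 gives the series a second readable value in this assay, and it shows that a much larger group on the saturated ring carbon can replace methyl without a change that stands out from the scatter (a 1.8-fold higher number from compound 2 to compound 4 (0.25 log units; within the scatter)). So the ring carbon of the 4-substituted piperidine accepts ethoxycarbonyl as well as methyl, and these two compounds alone do not show that activity here depends on which of the two groups is present. Against the other two compounds, the steps (an at least 1.7-fold lower number from compound 3 to compound 4 (0.23 log units; that floor lies within the scatter); an at least 1.7-fold lower number from compound 1 to compound 4 (0.23 log units; that floor lies within the scatter)) give only floors, and their full size cannot be read because those compounds sit at a limit: the limit of > 100000 nM in this assay, at which 2 of the 4 values shown sit.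

The compounds shown do not separate the two differences between compound 3 and the other piperidines, the hydroxyl and the place of the side chain on the ring; 4-(2-hydroxyethyl)piperidin-1-yl and 2-methylpiperidin-1-yl would each isolate one of them. They also leave open whether a carboxylic acid on the same ring carbon would fit the same picture as the ethyl ester.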